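The compounds below may be only part of what the source reports. "The series", "measured", "known", "first", "only" and "open" are said of these compounds alone.

Measured compounds in a functional assay on NALM-6 cells (Homo sapiens) for cytotoxicity, with a stated time of 72 h; a lower number here means that less compound is needed, a higher number that more compound is needed for the effect:

- compound 1 `C=C[C@@](C)(/C=C/c1ccc(OCc2ccccc2)cc1)CCC=C(C)C`: > 43400 nM (a limit)
- compound 2 `C=C[C@@](C)(/C=C/c1ccc(O)cc1)CC/C=C(C)/C=N/N`: > 43400 nM (a limit)
- compound 3 `C=C[C@@](C)(/C=C/c1ccc(O)c(/C=C/C(=O)OCC)c1)CCC=C(C)C`: 20900 nM

Compound 1 stands at the limit of > 43400 nM in this assay, at which 2 of the 3 values shown sit. Its entry is therefore a limit and not a number, so it gives no fixed point from which to measure a change. Compound 2 shares that position, and its entry is also only a limit. Compound 3 is the only one of the three with a number, at 20900 nM.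

The next compound is compound 4 `C=C[C@@](C)(/C=C/c1ccc(Nc2cc(F)cc(F)c2)cc1)CCC=C(C)C`. It keeps the core of compound 1, but (3,5-difluorophenyl)amino takes the place of benzyloxy on an aromatic carbon, para to a large group: (3,5-difluorophenyl)amino in place of benzyloxy on an aromatic carbon. Among the compounds with values here, no pair of measured compounds isolates an exchange of this kind, so the expectation is a loose one. Within the data shown here, the value of compound 3, 20900 nM, is the only guide to where a number might fall for a compound of this type in this assay. A modest move toward lower numbers is expected, and compound 4 may well remain at the limit. The estimated change is an at least 1.9-fold lower number from compound 1 to compound 4 (0.29 log units; that floor lies within the scatter). In this assay the expected value for compound 4 is 22000 nM, estimated to lie between 8000 nM and 43400 nM.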

Compound 4, half-maximal effective concentration: > 43400 nM
Compound 4 ended at the assay's limit; the forecaster's own chance of this, stated with the estimate: 40%; at least 1.9-fold (0.29 log units) between middle value and limit.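

In this assay compound 4 gives > 43400 nM, which is a limit and not a number. Within the data shown here, compound 1 also has only a limit, so no step between compound 1 and compound 4 can be read: the limit of > 43400 nM in this assay, at which 3 of the 4 values shown sit. The compounds shown leave open whether (3,5-difluorophenyl)amino in place of benzyloxy changes the effect at all.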